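From Cyclopropyl to 2-Bromophenyl on the Saturated Carbon

This account rests on a few compounds, and the source may have more. Where it says the series, first, only, none or still open, it means among the compounds named here.

Of the compounds shown here, three sharing one core have been measured in an assay on Sf9 cells for inhibition of serine/threonine-protein kinase 4 (Homo sapiens), read by luminescence and ADP-Glo, with a stated time of 1 h, in the presence of a further agent that is not named here; a lower number here means a stronger inhibitor, a higher number a weaker inhibitor. Compound 1 `CN1C(=O)C(C2CC2)N(C)c2nc(Nc3ccc(S(N)(=O)=O)cc3)ncc21` gives 136 nM, the lowest of the three numbers. Compound 2 `CN1C(=O)C(CC2CC2)N(C)c2nc(Nc3ccc(S(N)(=O)=O)cc3)ncc21` gives 211 nM, and compound 3 `CN1C(=O)C(c2ccccc2)N(C)c2nc(Nc3ccc(S(N)(=O)=O)cc3)ncc21` gives 383 nM. The step of a 1.6-fold higher number from compound 1 to compound 2 (0.19 log units; within the scatter) stays inside the scatter, whereas the step of a 2.8-fold higher number from compound 1 to compound 3 (0.45 log units; beyond the scatter) is a modest loss; the step of a 1.8-fold higher number from compound 2 to compound 3 (0.26 log units; within the scatter) again lies within the scatter.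

The unmeasured compound 4 `CN1C(=O)C(c2ccccc2Br)N(C)c2nc(Nc3ccc(S(N)(=O)=O)cc3)ncc21` differs from compound 1 in one place: 2-bromophenyl in place of cyclopropyl on a saturated ring carbon. The step that bears most directly on this change is a 2.8-fold higher number from compound 1 to compound 3 (0.45 log units; beyond the scatter), since compound 3 also carries a six-membered aromatic ring on the same saturated ring carbon. Among the compounds with values here, the bromine on that ring has no counterpart among the measured compounds, so its effect can only be guessed. The expectation is therefore a higher number for compound 4 than for compound 1, of about the size seen for compound 3 or somewhat larger, as a 3.7-fold higher number from compound 1 to compound 4 (0.57 log units; beyond the scatter). Compound 4 is estimated at 500 nM, within a range of 200 nM to 1300 nM.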

Compound 4, half-maximal inhibitory concentration: 57 nM
Estimate against measurement, compound 4: 8.8-fold (0.94 log units) above, outside the stated range (below it).
By their numbers in this assay, from the lowest: compound 4; then compounds 1, 2 and 3 (each within the scatter of the next, the first and the last beyond it).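

Compound 3 had suggested that a phenyl ring on this saturated ring carbon costs something, but the bromine changes that reading: bromo in place of hydrogen gives a 6.7-fold lower number from compound 3 to compound 4 (0.83 log units; beyond the scatter), so the substituent on the ring counts for more here than the presence of the ring itself. The 2-bromophenyl group also outdoes both smaller groups, with a 2.4-fold lower number from compound 1 to compound 4 (0.38 log units; beyond the scatter) and a 3.7-fold lower number from compound 2 to compound 4 (0.57 log units; beyond the scatter), which leaves compound 4 as the strongest inhibitor of the four. Nothing measured here accounts for what the bromine does.

The compounds shown leave open whether chlorine, methyl or methoxy on the phenyl ring would act as bromine does, and whether bromine on another carbon of that ring would give a similar number. As far as these compounds go, how a phenyl ring bearing an amine or a carboxylic acid would fare at this position also remains open.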